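Removing the amide nitrogen methyl: expected effect on inhibition

The source may report more compounds than this note shows. Statements on the series, on what has been measured and on what is new or still open speak of the compounds shown alone.

Of the compounds shown here, three have been read in a functional assay on the whole organism with Rattus norvegicus as the target, with a stated time of 3 h, at a dose of 20 mg/kg by the oral route; on this read-out lower numbers stand for less inhibition and higher numbers for more inhibition at the one dose given (going by the name of the read-out). Compound 1 `CNC(=O)/C=C1\CCc2c(C)cc(F)cc21` gives 15% in this assay. Compound 2 `NC(=O)/C=C1\CCc2c(F)cc(Cl)cc21` gives 34%, and compound 3 `CNC(=O)/C=C1\CCc2cc(Cl)cc(Cl)c21` gives 0%. Compound 1 thus stands second highest of the three, with compound 3 beyond the scatter below it and compound 2 further beyond the scatter above it.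

Compound 4 `Cc1cc(F)cc2c1CC/C2=C\C(N)=O` is not yet measured. It differs from compound 1 in one place: hydrogen in place of methyl on an amide-type nitrogen. Going by the values given here, no measured pair differs in this place alone. Among the compounds with values here, compound 2 is the only measured compound with the amino form of the amide and gives the highest number, so an upward step beyond the scatter is expected. The expected step is a number 13 percentage points higher from compound 1 to compound 4 (beyond the scatter). For compound 4 the estimate is 28%, in the range 10% to 48%.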

Compound 4, a percentage reported as inhibition, in the whole organism at one dose (the size of the read-out at that dose, not a potency): 11%
For compound 4 the middle estimate is 17 percentage points above the measured one, and the stated range covers the measured number.
By their numbers in this assay, from the lowest: compound 3; then compounds 4 and 1 (each within the scatter of the next); then compound 2.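

In this assay, going by these compounds alone, the first one-place reading of hydrogen in place of methyl on the amide-type nitrogen is a number 4 percentage points lower from compound 1 to compound 4 (within the scatter) and sets the two compounds level on the core of compound 1. The amino form of the amide is therefore not enough by itself to lift the number on this core. No measurement on hand explains this result.

This single pair leaves open whether the same swap behaves alike on cores with other ring substituents. Also open, on these data alone, is how an ethyl group on this nitrogen, or a carboxylic acid in place of the amide, would read.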